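The source may hold more compounds than are shown below. What is called first, only, known or untested is meant among the compounds shown, and "the series" means these compounds.

Compound 1 `Cc1cc(C(=O)O)nn1-c1ccc(S(=O)(=O)N2CCC(=O)N(C3CCCCC3)C2=S)cc1` and compound 2 `CCCCN1C(=O)CCN(S(=O)(=O)c2ccc(-n3nc(C(=O)O)cc3C)cc2)C1=S` both carry a carboxy group on the five-membered aromatic ring with two nitrogens. In a functional assay on the whole organism (blood, strain albino) with Mus musculus as the target, with stated times of 6 days and 3 h, at a dose of 1 mmol/kg by the oral route (on this read-out lower numbers stand for less inhibition and higher numbers for more inhibition at the one dose given (going by the name of the read-out)), compound 1 gives 2% and compound 2 gives 2%. Within the data shown here, the one charted step, no change at the digits printed from compound 1 to compound 2 (within the scatter), touches a different part of the molecule. Compound 3 `CCN1C(=O)CCN(S(=O)(=O)c2ccc(-n3nc(C)cc3C)cc2)C1=S` carries two methyl groups on that ring and gives 4% in this assay, the highest of the three readings but within the scatter of both others. Compound 4 `CCN1C(=O)CCN(S(=O)(=O)c2ccc(-n3nc(C(=O)O)cc3C)cc2)C1=S` differs from compound 3 by carboxy in place of methyl on an aromatic carbon. Among the measured compounds shown here, no measured step covers this change, yet compounds 1 and 2 already hold the carboxy group and read close to compound 3, so nothing beyond the scatter is expected: a number 2 percentage points lower from compound 3 to compound 4 (within the scatter). Compound 4 is estimated at 2%, between 0% and 8%.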

Compound 4, a percentage reported as inhibition, in the whole organism at one dose (the size of the read-out at that dose, not a potency): 1%
The estimate for compound 4 lay 1 percentage points above the measured number; measured number inside the range.
By their numbers in this assay, from the lowest: compounds 4, 1, 2 and 3 (each within the scatter of the next).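

Carboxy in place of methyl on this aromatic carbon, the change from 3,5-dimethyl-1H-pyrazol-1-yl to 3-carboxy-5-methyl-1H-pyrazol-1-yl, is now tested directly in this assay and leaves the reading unchanged within the scatter (a number 3 percentage points lower from compound 3 to compound 4 (within the scatter)). With carboxy in place, ethyl on the amide-type nitrogen reads like butyl (a number 1 percentage points lower from compound 2 to compound 4 (within the scatter)) and cyclohexyl (a number 1 percentage points lower from compound 1 to compound 4 (within the scatter)). No measurement here offers an explanation for these readings. Going by these compounds, what an amine or a primary amide would do on this same aromatic carbon stays open.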